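Working notes: replacing cyclohexyl on the urea nitrogen

The source may report more compounds than this note shows. Statements on the series, on what has been measured and on what is new or still open speak of the compounds shown alone.

Measured so far:
compound 1 `Cn1cccc(C(=O)NCCC2CCN(S(=O)(=O)NC(=O)NC[C@@H]3C[C@@H]4C=C[C@@H]3C4)CC2)c1=O`: 40%
compound 2 `O=C(NC1CCCCC1)NS(=O)(=O)N1CCC(CCNC(=O)c2cccc3c2OCCO3)CC1`: 42%

In a functional assay on the whole organism (blood) with Rattus norvegicus as the target, with stated times of 24 h and 1 h, at a dose of 15 mg/kg by the intraperitoneal route (on this read-out higher numbers stand for a stronger effect at the one dose given and lower numbers for a weaker effect), compound 1 gives 40% and compound 2 gives 42%. Compound 2 holds the higher of the two numbers, but the gap to compound 1 lies within the scatter, so the two are read as equal. Among the compounds with values here, no step between compounds differing in one place is available.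

Compound 3 `O=C(NC[C@@H]1C[C@@H]2C=C[C@@H]1C2)NS(=O)(=O)N1CCC(CCNC(=O)c2cccc3c2OCCO3)CC1` is not yet measured in this assay. It differs from compound 2 as follows: a group of 8 heavy atoms (8 carbon; 2 five-membered non-aromatic rings of carbon only) in place of a group of 6 heavy atoms (6 carbon; one six-membered non-aromatic ring of carbon only), on an amide-type nitrogen. The entering group of 8 heavy atoms with 2 five-membered non-aromatic rings is the same group that compound 1 carries on an amide-type nitrogen, and with that group compound 1 reads 40%, which lies within the scatter of compound 2. On that basis no step beyond the scatter is expected from compound 2 to compound 3 in this assay; the expected step is a number 1 percentage points lower from compound 2 to compound 3 (within the scatter). For compound 3 the estimated value is 41%, with a range from 28% to 54%.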

Compound 3, a percentage reported as activity, at one dose (the size of the read-out at that dose, not a potency): 40%
The estimate for compound 3 lay 1 percentage points above the measured number; measured number inside the range.
By their numbers in this assay, from the lowest: compounds 1, 3 and 2 (each within the scatter of the next).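

In this assay, placing the group of 8 heavy atoms with 2 five-membered non-aromatic rings on the amide-type nitrogen in place of cyclohexyl gives a number 2 percentage points lower from compound 2 to compound 3 (within the scatter) and so, with the shared core held constant, this position accepts a larger all-carbon group, with 1 double bond and 3 defined stereocentres, without a step beyond the scatter. At the other end of the molecule, the group of 10 heavy atoms in place of the group of 8 heavy atoms on the carbonyl carbon gives no change at the digits printed from compound 1 to compound 3 (within the scatter) and thus adds a second one-place comparison, also without a step beyond the scatter. No measurement here bears on why these exchanges leave the read-out level.

On these data alone, both groups compared on the amide-type nitrogen are all-carbon, with 0 hydrogen-bond donors and 0 hydrogen-bond acceptors, so the effect of a group carrying an amine or a carboxylic acid at this position remains open. Also open, as far as these compounds go, are a longer open chain at this position and whether these compounds would stay level at other doses, as the read-out reports the size of the effect at one dose and not a potency.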